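From fluoro to amino: what compound 3 may show

The source may hold more compounds than are shown below. What is called first, only, known or untested is meant among the compounds shown, and "the series" means these compounds.

Compound 1 (`Nc1nc(Nc2ccc(S(N)(=O)=O)cc2)sc1C(=O)c1ccccc1[N+](=O)[O-]`): 560 nM
Compound 2 (`Nc1nc(Nc2ccc(S(N)(=O)=O)cc2)sc1C(=O)c1cccc(F)c1`): 1100 nM

Going by the values given here, in a functional assay on SK-ES1 cells (Homo sapiens) for cytotoxicity, read by fluorescence and resazurin assay, with a stated time of 72 h (on this read-out higher numbers stand for weaker inhibition and lower numbers for stronger inhibition), compound 2 gives 1100 nM and cannot be separated from compound 1, the only other compound measured, as the comparison shows a 2.0-fold higher number from compound 1 to compound 2 (0.29 log units; within the scatter) within the usual variation between repeats.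

The next compound, compound 3 (`Nc1cccc(C(=O)c2sc(Nc3ccc(S(N)(=O)=O)cc3)nc2N)c1`), departs from compound 2 in one place (amino in place of fluoro on an aromatic carbon), with amino in place of fluoro on an aromatic carbon, meta to a large group. The group on the carbonyl thus changes from 3-fluorophenyl to 3-aminophenyl.

Among the compounds with values here, only one measured step bears on this, and only indirectly. Exchanging 2-nitrophenyl for 3-fluorophenyl on a carbonyl carbon gave a 2.0-fold higher number from compound 1 to compound 2 (0.29 log units; within the scatter) and so stayed within the scatter. Within the data shown here, no measured compound carries amino, so the data offer no direct guide. No step beyond the scatter is therefore expected in this assay in either direction, although the range must stay wide. The expected change is a 1.4-fold lower number from compound 2 to compound 3 (0.14 log units; within the scatter) in this estimate. Compound 3 is expected at 800 nM, with an estimated range of 250 nM to 2500 nM.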

Compound 3, half-maximal inhibitory concentration: 9800 nM
For compound 3 the middle estimate is 12-fold (1.09 log units) below the measured one; the whole stated range lies below it.
By their numbers in this assay, from the lowest: compounds 1 and 2 (each within the scatter of the next); then compound 3.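

In this assay, going by these compounds alone, amino in place of fluoro on an aromatic carbon, meta to a large group, gave an 8.9-fold higher number from compound 2 to compound 3 (0.95 log units; beyond the scatter) and is the first single exchange here to move the number beyond the scatter. Compared with the 2-nitrophenyl group on the carbonyl carbon, the 3-aminophenyl group gave an 18-fold higher number from compound 1 to compound 3 (1.24 log units; beyond the scatter), so the group at this site can shift the read-out clearly, even though the exchange between 2-nitrophenyl and 3-fluorophenyl did not. The change replaces one heavy atom with one heavy atom and adds a hydrogen-bond donor and a hydrogen-bond acceptor, but nothing available here accounts for the shift.

On these data alone, whether a hydroxyl group, a methoxy group or an acetylated amine on the same carbon would read like fluoro or like amino remains open. As far as these compounds go, it is also open whether a methylamine or a dimethylamine would keep the higher number seen with the amino group, and whether the same step would appear in other cells.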